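This account rests on a few compounds, and the source may have more. Where it says the series, first, only, none or still open, it means among the compounds named here.

Measured in a functional assay on the whole organism for activation, with Mus musculus as the target, with a stated time of 60 min; a higher number here means that more compound is needed for the effect, a lower number that less compound is needed:
- compound 1 `N#Cc1ccc(-c2ccc(/C=N/N3C(=O)NC(=O)C3O)o2)cc1`: > 1000 mg/kg
- compound 2 `Nc1ccc(-c2ccc(/C=N/N3C(=O)NC(=O)C3O)o2)cc1`: > 1000 mg/kg
- compound 3 `O=C1NC(=O)N(/N=C/c2ccc(-c3ccc([N+](=O)[O-])cc3)o2)C1O`: > 1000 mg/kg

Each of these entries is a limit and not a number. Compound 3 therefore stands at > 1000 mg/kg, which is only a limit, and the other two share it: the limit of > 1000 mg/kg in this assay, at which 3 of the 3 values shown sit.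

Compound 4 `O=C1NC(=O)N(/N=C/c2ccc(-c3ccc(F)cc3)o2)C1O` has fluoro in place of nitro on an aromatic carbon. The measured changes at that carbon are a step that the two limits leave unreadable from compound 1 to compound 3 and a step that the two limits leave unreadable from compound 2 to compound 3. Neither has a readable size, so neither gives a direction. No step beyond the scatter is therefore expected in this assay. The expected step is a number no higher from compound 3 to compound 4 (the limit leaves the size open). For compound 4 the estimate is 1000 mg/kg. The expected range runs from 500 mg/kg to 2000 mg/kg.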

Compound 4, dose for half-maximal effect: > 1000 mg/kg
Compound 4 ended at the assay's limit; the forecaster's own chance of this, stated with the estimate: 85%; the middle value sits exactly at the limit.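

No step can be read between compound 4 and compounds 1, 2 and 3, since all four values are limits and not numbers: the limit of > 1000 mg/kg in this assay, at which 4 of the 4 values shown sit. The compounds shown leave open what dose of any of them would reach half-maximal effect in this assay and whether the four groups differ at all.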